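Swapping a Tert-Butyl for a Hydroxyethyl in Cytotoxicity

The source may report more compounds than this note shows. Statements on the series, on what has been measured and on what is new or still open speak of the compounds shown alone.

Of the compounds shown here, three have been tested in an ADME assay on BaF3 cells (Mus musculus) for cytotoxicity; on this read-out lower numbers stand for an effect already at smaller amounts and higher numbers for an effect only at larger amounts of compound. Compound 1 `FC(F)(F)c1ccc(Nc2cc(-c3ccncc3)ncn2)cc1` gives only the limit of the method, > 10000 nM in this assay. Compound 3 `NC(=O)c1ccccc1-c1cc(Nc2ccc(OC(F)(F)F)cc2)ncn1` likewise gives only the limit, > 10000 nM. Among the measured compounds shown here, compound 2 `CC(C)(C)n1ncc2c(Nc3ccc(OC(F)(F)F)cc3)ncnc21` is the one that yields a number, 7300 nM, so it stands as the single measured point among the three, the other two resting at the limit of > 10000 nM in this assay, at which 2 of the 3 values shown sit.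

Compound 4 `OCCn1ncc2c(Nc3ccc(OC(F)(F)F)cc3)ncnc21` has not yet been measured. It differs from compound 2 in one place: 2-hydroxyethyl in place of tert-butyl on an aromatic nitrogen. For the measured compounds named here, no pair of measured compounds differs in only one place, so there is no measured step to lean on, and the values shown give no indication of what a tert-butyl or a 2-hydroxyethyl does on this read-out. The expectation is therefore a shift of modest size, a 1.2-fold higher number from compound 2 to compound 4 (0.09 log units; within the scatter), leaning toward an effect only at larger amounts of compound. Compound 4 is thus expected to give about 9000 nM in this assay, within a range from 4000 nM to 20000 nM, with a real chance that the method reports only its limit rather than a number.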

Compound 4, half-maximal effective concentration: > 10000 nM
Compound 4 ended at the assay's limit (the forecaster's own chance of this, stated with the estimate: 45%); middle value at least 1.1-fold (0.04 log units) from the limit.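

Among the compounds shown here, this is the first step that can be read at this position, on an aromatic nitrogen of the five-membered ring: in this assay, putting 2-hydroxyethyl in place of tert-butyl gives an at least 1.3-fold higher number from compound 2 to compound 4 (0.13 log units; that floor lies within the scatter). In this assay compound 4 gives > 10000 nM, which is a limit of the method and not a number. The step is therefore only a floor, so the true gap may be much wider or may stay within the usual scatter, yet the change clearly brings no effect at smaller amounts, even though the entering group carries a hydrogen-bond donor and the leaving group none, and compound 2 remains the only compound with a number, with the others sharing one ceiling: the limit of > 10000 nM in this assay, at which 3 of the 4 values shown sit.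

The compounds shown leave open how far past the limit compound 4 really lies, and so how large this step is. They also leave open what an amine, a carboxylic acid or a longer chain on the same aromatic nitrogen would do, and whether any of these would give a number rather than the limit.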